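Bromine on the core of a dichloroanilino pyrimidine

This account rests on a few compounds, and the source may have more. Where it says the series, first, only, none or still open, it means among the compounds named here.

Compound 1, `CCCN(CC1CC1)c1cc(Nc2c(Cl)cc(Cl)cc2Cl)nc(C)n1`, is the reference point of this account. Within the data shown here, in an assay on isolated protein for binding affinity to corticotropin-releasing factor receptor 1 (Homo sapiens) (on this read-out higher numbers stand for weaker inhibition and lower numbers for stronger inhibition), compound 1 gives 30 nM, the lower of the two numbers measured so far. Among the measured compounds shown here, the only other measured compound, compound 2, `CCCN(CC1CC1)c1cc(Nc2cc(Cl)c(Cl)cc2Cl)nc(C)n1`, carries its three chlorine atoms in a different arrangement on the anilino ring; in this assay compound 2 gives 253 nM, a gap from compound 1 that lies beyond the usual scatter. For the measured compounds named here, no single-point step connects these two compounds, so their values are reported side by side without further reading.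

The next compound, compound 3, `CCCN(CC1CC1)c1nc(C)nc(Nc2c(Cl)cc(Cl)cc2Cl)c1Br`, is built from compound 1 by one change: bromo in place of hydrogen on an aromatic carbon. Going by the values given here, nothing measured so far speaks directly to this change, so any expectation rests on compound 1 alone. The step is expected to be small, a modest move toward a lower number, close to the edge of the scatter: the step from compound 1 to compound 3 is estimated at a 2.0-fold lower number from compound 1 to compound 3 (0.30 log units; within the scatter). Compound 3 is therefore expected to give about 15 nM in this assay, within a range from 5 nM to 45 nM.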

Compound 3, inhibition constant: 2 nM
Compound 3: middle estimate off by 7.5-fold (0.88 log units), on the high side; measured number outside the range, below it.
By their numbers in this assay, from the lowest: compound 3; then compound 1; then compound 2.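

Bromo in place of hydrogen on this aromatic carbon, ortho to the (cyclopropylmethyl)(propyl)amino group and para to the methyl group, turns out to be a large step rather than a marginal one: in this assay the change gives a 15-fold lower number from compound 1 to compound 3 (1.18 log units; beyond the scatter). The earlier compounds shown here both carry hydrogen at this carbon and so could not show that the position responds at all, whereas here the entry of a bromine atom alone, with no ring, no hydrogen-bond donors or acceptors and no net charge, moves the number well beyond the scatter. No separate measurement accompanies this step, and what lies behind its size therefore stays unexplained.

Whether chloro, a methyl group or a nitrile on this same carbon would move the number as far as bromo does remains an open question. As far as these compounds go, it is equally open whether the step would carry over to compound 2, with its different arrangement of chlorine atoms on the anilino ring, since the effect of bromo is read here on a single pair of compounds.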